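The source may report more compounds than this note shows. Statements on the series, on what has been measured and on what is new or still open speak of the compounds shown alone.

Working notes on the series. In an ADME assay on cells (Hepatocyte, Homo sapiens) for metabolic stability, with a stated time of 30 min (a higher number here means that more of the compound is left, a lower number that less of the compound is left), compound 2 (`O=C(OC1CCC(CN2CCN(c3cc(=O)c4cc(C(F)(F)F)cc([N+](=O)[O-])c4s3)CC2)CC1)C1CCCCC1`) gives 2.8%, the lower of the two numbers in hand, while compound 1 (`CS(=O)(=O)NC1CCC(CN2CCN(c3cc(=O)c4cc(C(F)(F)F)cc([N+](=O)[O-])c4s3)CC2)CC1`) gives 105%.

Compound 3 (`O=C(OC1CCC(CN2CCN(c3cc(=O)c4cc(C(F)(F)F)cc([N+](=O)[O-])c4s3)CC2)CC1)c1cccs1`) differs from compound 2 on a carbonyl carbon, with thiophen-2-yl in place of cyclohexyl on a carbonyl carbon. A five-membered aromatic ring thus replaces a six-membered non-aromatic ring of carbon only, and the rest of the structure is unchanged.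

Going by the values given here, only one measured step bears on this, and only indirectly: a number 102.2 percentage points lower from compound 1 to compound 2 (beyond the scatter). That large step, beyond the scatter, exchanged methanesulfonamido for (cyclohexylcarbonyl)oxy. Among the compounds with values here, compound 3 keeps the carbonyl and its oxygen, and no measured step varies the group on that carbonyl carbon. With compound 2 at 2.8%, the number has little room to fall further.

No step beyond the scatter is expected in this assay, and the expected change is a number 2.2 percentage points higher from compound 2 to compound 3 (within the scatter). The estimate for compound 3 is 5%, with an expected range of 1% to 22%.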

Compound 3, percent of the compound remaining: 2.2%
The estimate for compound 3 lay 2.8 percentage points above the measured number, within the range that was stated.
By their numbers in this assay, from the lowest: compounds 3 and 2 (each within the scatter of the next); then compound 1.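

In this assay, going by these compounds alone, the group on the carbonyl carbon is varied here for the first time, and thiophen-2-yl in place of cyclohexyl gives a number 0.6 percentage points lower from compound 2 to compound 3 (within the scatter) so this change does not separate the two compounds, with an aromatic and a non-aromatic ring in this place giving numbers within the scatter of each other. The large drop seen earlier also recurs with the new group, as a number 102.8 percentage points lower from compound 1 to compound 3 (beyond the scatter) shows, so among the compounds shown the low number is not tied to cyclohexyl and holds for both carbonyl-bearing groups set against methanesulfonamido. No measured data on the fate of these compounds accompany the numbers to account for this result.

Both carbonyl-bearing compounds lie close to the bottom of the scale, so the compounds shown cannot tell whether a further change on the carbonyl carbon has any effect in this range or whether the linking oxygen governs the result. An amide carrying the same cyclohexylcarbonyl, or a methyl group or an amine on the carbonyl carbon, could show whether the number stays near that of compound 2 or moves towards that of compound 1.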